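The source may hold more compounds than are shown below. What is called first, only, known or untested is meant among the compounds shown, and "the series" means these compounds.

Among the compounds with values here, the three compounds measured so far share a common core and differ only in the group on the carbonyl carbon. Compound 1 `CCN(CC)S(=O)(=O)c1ccc(S(=O)(=O)N2CCC[C@@H](C(=O)N3CCC(O)CC3)C2)cc1` gives 870 nM in a functional assay on MIA PaCa-2 cells (Homo sapiens) for inhibition, read by MTT assay, with a stated time of 7 days; a lower number here means a stronger inhibitor, a higher number a weaker inhibitor. Compound 2 `CCN(CC)S(=O)(=O)c1ccc(S(=O)(=O)N2CCC[C@@H](C(=O)N3CC[C@@H](OC)C3)C2)cc1` gives 3910 nM, and compound 3 `CCN(CC)S(=O)(=O)c1ccc(S(=O)(=O)N2CCC[C@@H](C(=O)N[C@H]3CC[C@@H](OC)CC3)C2)cc1` gives 960 nM. Among these three numbers compound 3 stands second highest, its nearest neighbour being compound 1, from which it differs by a margin within the scatter; the step of a 4.1-fold lower number from compound 2 to compound 3 (0.61 log units; beyond the scatter) is the only one that sets it apart.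

Compound 4 `CCN(CC)S(=O)(=O)c1ccc(S(=O)(=O)N2CCC[C@@H](C(=O)N3CCC(COC)CC3)C2)cc1` is built from the same atoms as compound 3, joined differently: 4-(methoxymethyl)piperidin-1-yl in place of (4-methoxycyclohexyl)amino on a carbonyl carbon. Two earlier steps bear on this. The step of a 1.1-fold higher number from compound 1 to compound 3 (0.04 log units; within the scatter) shows that a six-membered group on the carbonyl carbon, whether bound through nitrogen or through a ring carbon, gave about the same number. The step of a 4.5-fold higher number from compound 1 to compound 2 (0.65 log units; beyond the scatter) shows that a smaller, five-membered group cost activity. Compound 4 keeps a six-membered ring, so a step near a 1.3-fold higher number from compound 3 to compound 4 (0.10 log units; within the scatter) is expected for compound 4, with the number for compound 4 estimated at 1200 nM, within 500 nM to 3000 nM.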

Compound 4, half-maximal inhibitory concentration: 250 nM
Beside the measured number, compound 4's estimate is 4.8-fold (0.68 log units) above it, outside the stated range (below it).
By their numbers in this assay, from the lowest: compound 4; then compounds 1 and 3 (each within the scatter of the next); then compound 2.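

On the carbonyl carbon, two groups built from the same atoms do not read alike: 4-(methoxymethyl)piperidin-1-yl in place of (4-methoxycyclohexyl)amino gives a 3.8-fold lower number from compound 3 to compound 4 (0.58 log units; beyond the scatter), so a six-membered ring alone does not set the number. The group on the ring carbon also matters, since methoxymethyl in place of hydroxy gives a 3.5-fold lower number from compound 1 to compound 4 (0.54 log units; beyond the scatter). Set against 3-methoxypyrrolidin-1-yl, the same entering group gives a 16-fold lower number from compound 2 to compound 4 (1.19 log units; beyond the scatter), the widest step among these compounds.

Nothing available here accounts for these differences. Going by these compounds, it remains open whether an ethoxymethyl or aminomethyl group in place of methoxymethyl on that ring carbon would keep, improve or lose the number seen for compound 4.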